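Methoxy additions on a bromoacrylamide chalcone series

The source may report more compounds than this note shows. Statements on the series, on what has been measured and on what is new or still open speak of the compounds shown alone.

Compound 1: `C=C(Br)C(=O)Nc1ccc(/C=C/C(=O)c2ccccc2)cc1`, 3900 nM
Compound 2: `C=C(Br)C(=O)Nc1ccc(/C=C/C(=O)c2cccc(OC)c2)cc1`, 700 nM
Compound 3: `C=C(Br)C(=O)Nc1ccc(C(=O)/C=C/c2cc(OC)cc(OC)c2)cc1`, 1700 nM

In a functional assay on HeLa cells (Homo sapiens) for antiproliferative activity, with a stated time of 48 h (on this read-out higher numbers stand for weaker inhibition and lower numbers for stronger inhibition), compound 1 gives 3900 nM, and compound 2 gives 700 nM. The change between them is methoxy in place of hydrogen on an aromatic carbon, and it produced a 5.6-fold lower number from compound 1 to compound 2 (0.75 log units; beyond the scatter). Compound 3 gives 1700 nM in this assay, a higher number than compound 2 and a lower number than compound 1; the difference between the core of compound 3 and the core of compound 1 is not broken down here.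

Compound 4, `C=C(Br)C(=O)Nc1ccc(C(=O)/C=C/c2cc(OC)c(OC)c(OC)c2)cc1`, is not yet measured. It differs from compound 3 by methoxy in place of hydrogen on an aromatic carbon. This is the same kind of change as that from compound 1 to compound 2, not the same: in compound 2 the incoming methoxy sits meta to a large group, whereas in compound 4 it sits ortho to two methoxy groups and para to a large group. Because the earlier step gave a 5.6-fold lower number from compound 1 to compound 2 (0.75 log units; beyond the scatter), compound 4 is expected to show a 2.8-fold lower number from compound 3 to compound 4 (0.45 log units; beyond the scatter) in this assay. The estimated value for compound 4 is 600 nM, expected to lie between 150 nM and 2500 nM.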

Compound 4, half-maximal inhibitory concentration: 420 nM
Compound 4: the middle estimate sits 1.4-fold (0.15 log units) above what was measured; the measured number falls inside the stated range.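

In this assay, methoxy in place of hydrogen on an aromatic carbon gave a 4.0-fold lower number from compound 3 to compound 4 (0.61 log units; beyond the scatter). Set beside the earlier step, the same change lowered the number on both cores, and the two steps cannot be told apart in size: the same change on two cores in this assay, a 5.6-fold lower number (0.75 log units; beyond the scatter) from compound 1 to compound 2 and a 4.0-fold lower number (0.61 log units; beyond the scatter) from compound 3 to compound 4, 1.4-fold (0.14 log units) apart, within the scatter of two such steps This shows that the change carried over between these two cores in this one assay, but two cores are too few to show that it would carry to others, and the incoming methoxy sits in a different place in each step, so the effect of the core cannot be separated from that of the position.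

The compounds shown leave open whether another group at the place ortho to two methoxy groups and para to a large group, such as a hydroxyl, an amine or an ethoxy, would give a step of similar size. Also open, going by these compounds, is how the number would respond if chlorine or hydrogen replaced the bromine of the acrylamide, which all four compounds share.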